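Diethylamino in place of dimethylamino: compound 3

The compounds below may be only part of what the source reports. "The series", "measured", "known", "first", "only" and "open" are said of these compounds alone.

Measured in an ADME assay on microsomes from liver (Rattus norvegicus) for metabolic stability, using NADPH, with a stated time of 10 min (a higher number here means that more of the compound is left, a lower number that less of the compound is left), so far:

Compound 1 `NC(=O)NC/C=C/CN(C[C@H]1Cc2ncccc2CN1)[C@H]1CCCc2cccnc21` gives 1% here
Compound 2 `CN(C)CCCCN(C[C@H]1Cc2ncccc2CN1)[C@H]1CCCc2cccnc21` gives 27% here

Compound 2 stands higher of the two, with 27% in this assay as its reading. Compound 3 `CCN(CC)CCCCN(C[C@H]1Cc2ncccc2CN1)[C@H]1CCCc2cccnc21` is next, and its change is diethylamino in place of dimethylamino on a saturated chain carbon, four bonds along the chain from an amine nitrogen with the rest of the structure kept. Among the measured compounds shown here, the only measured step bearing on this is a number 26 percentage points higher from compound 1 to compound 2 (beyond the scatter) and it is modest. For the measured compounds named here, that step replaces a larger end group of a different kind, and no measured step exchanges dimethylamino for diethylamino, so it gives only a loose guide. A small downward move is expected, which may stay within the scatter. The expected step is a number 7 percentage points lower from compound 2 to compound 3 (within the scatter) in this assay on this reasoning. For compound 3 the estimated value is 20% with an expected range from 5% to 40% as the working figure.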

Compound 3, percent of the compound remaining: 6%
The estimate for compound 3 lay 14 percentage points above the measured number, within the range that was stated.
By their numbers in this assay, from the lowest: compounds 1 and 3 (each within the scatter of the next); then compound 2.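

At the saturated chain carbon four bonds along the chain from an amine nitrogen, diethylamino in place of dimethylamino gives, in this assay, a number 21 percentage points lower from compound 2 to compound 3 (beyond the scatter), so exchanging the groups on the terminal nitrogen is enough to move the reading. The comparison with the different end group gives a number 5 percentage points higher from compound 1 to compound 3 (within the scatter), so among these three compounds only the dimethylamino end of compound 2 stands apart. Nothing measured here accounts for the change.

Still open, as far as these compounds go, is whether a smaller end such as methylamino or a bare primary amine would match or exceed compound 2, and whether a ring such as pyrrolidine or morpholine would behave like dimethylamino or like diethylamino. A shorter or longer chain carrying dimethylamino also remains to be placed against compound 2 in this assay.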